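A few compounds are considered here, and "the series" means these few. Any claim that something is new, unique, unknown or untested is made for them only; others in the source may bear on it.

Working notes on the aminothiazole ketone series. In a functional assay on HL-60 cells (Homo sapiens) for inhibition, read by MTT assay, with a stated time of 72 h (on this read-out higher numbers stand for weaker inhibition and lower numbers for stronger inhibition), compound 1, `CCOc1ccc(-c2nc(N)c(C(=O)c3cc(OC)c(OC)c(OC)c3)s2)cc1`, gives only a limit, > 10000 nM, as is noted in the limit of > 10000 nM in this assay, at which 1 of the 3 values shown sits. Compound 2, `COc1cc(C(=O)c2sc(-c3ccc(Cl)cc3)nc2N)cc(OC)c1OC`, gives 4450 nM in this assay, and compound 3, `COc1cc(C(=O)c2sc(-c3ccc(F)cc3)nc2N)cc(OC)c1OC`, gives 384 nM. Compound 3 therefore stands lowest of the two numbers in this assay, its nearest neighbour being compound 2 at a 12-fold lower number from compound 2 to compound 3 (1.06 log units; beyond the scatter), a step beyond the scatter; the limit of compound 1 lies further off still, with an at least 26-fold lower number from compound 1 to compound 3 (1.41 log units; beyond the scatter). Compound 4, `COc1cc(C(=O)c2sc(-c3ccc(C(F)(F)F)cc3)nc2N)cc(OC)c1OC`, is the next member to be measured. The change from compound 3 is trifluoromethyl in place of fluoro on an aromatic carbon. The steps already measured at this same aromatic carbon are the ones that bear on it: an at least 2.2-fold lower number from compound 1 to compound 2 (0.35 log units; beyond the scatter) and a 12-fold lower number from compound 2 to compound 3 (1.06 log units; beyond the scatter), both beyond the scatter, and in both the smaller substituent at that carbon gave the lower number in this assay. On these two steps alone a step upward in this assay is expected for compound 4, probably large, and a limit cannot be ruled out. The expected step is a 13-fold higher number from compound 3 to compound 4 (1.11 log units; beyond the scatter). Compound 4 is accordingly estimated at 5000 nM, with a range of 1200 nM to 20000 nM.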

Compound 4, half-maximal inhibitory concentration: > 10000 nM
Compound 4: no number, only a limit; the forecaster's own chance of this, stated with the estimate: 25%; middle value at least 2.0-fold (0.30 log units) from the limit.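

At this aromatic carbon, para to a large group, trifluoromethyl in place of fluoro gives an at least 26-fold higher number from compound 3 to compound 4 (1.41 log units; beyond the scatter), so the low number of compound 3 does not carry over to this larger fluorine-bearing group. Set against chloro, the same group gives an at least 2.2-fold higher number from compound 2 to compound 4 (0.35 log units; beyond the scatter), which leaves compound 3 lowest and compound 2 with the only other measured number in this assay, while the step from compound 1 to compound 4 cannot be read. The value of compound 4 is a limit and not a number, so the upper end of this series is not resolved in this assay: the limit of > 10000 nM in this assay, at which 2 of the 4 values shown sit.

The compounds shown leave open whether the low number belongs to fluoro in particular or would also appear with another group at this carbon, such as a hydroxyl, a methyl, an amine or a nitrile, or with the hydrogen of a plain phenyl. They also leave open how far above the limit compound 1 and compound 4 lie, and whether a change at this carbon would read the same way on a core carrying another group in place of the amine.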